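This account rests on a few compounds, and the source may have more. Where it says the series, first, only, none or still open, it means among the compounds named here.

Measured so far:
compound 1 `COC(=O)c1c(-c2ccccn2)n(Cc2ccc(Cl)cc2)c(-c2ccccn2)cc1=O`, in an ADME assay on J774.1 cells (Mus musculus) for cytotoxicity, with a stated time of 48 h; a higher number here means that more compound is needed for the effect, a lower number that less compound is needed: > 100 uM
compound 2 `COC(=O)C1C(=O)C(C(=O)OC)[C@H](c2cccc([N+](=O)[O-])c2)N(Cc2ccc(OC)cc2)[C@@H]1c1cccc([N+](=O)[O-])c1`, in this assay: > 100 uM

The value for compound 1 is a limit of the assay, not a number. The value for compound 2 is likewise a limit and not a number. Compound 2 therefore stands at the ceiling of what this assay reports, and it does not stand alone there: the limit of > 100 uM in this assay, at which 2 of the 2 values shown sit. With two limits and no numbers, nothing can be said about an order between compound 1 and compound 2.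

Compound 3 `COC(=O)C1C(=O)C(C(=O)OC)[C@H](c2cccc([N+](=O)[O-])c2)N(Cc2ccccc2)[C@@H]1c1cccc([N+](=O)[O-])c1` differs from compound 2 in one place, (hydrogen in place of methoxy on an aromatic carbon). Among the compounds with values here, no step between two measured compounds covers this change, so its size cannot be read from the data in hand. Because compound 2 sits at > 100 uM, the expectation is a step of no size beyond the scatter, and most likely the assay again returns only a limit for compound 3. The step expected in this assay is a step that the limit leaves unreadable from compound 2 to compound 3. Compound 3 is estimated at 150 uM, within 60 uM to 400 uM.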

Compound 3, concentration for half-maximal effect: > 100 uM
Compound 3: only a limit was reported; the forecaster's own chance of this, stated with the estimate: 80%; the middle value does not contradict the limit.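

In this assay compound 3 gives > 100 uM, a limit of the assay and not a number. Compound 2 also returns only a limit, so no step can be read between compound 2 and compound 3: the limit of > 100 uM in this assay, at which 3 of the 3 values shown sit.

The compounds shown leave open whether 4-methoxybenzyl to benzyl changes the read-out at all, and at what concentration any of them would reach half-maximal effect in this assay.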